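Tail change on compound 2: neopentyl to 2-methylphenyl

The source may report more compounds than this note shows. Statements on the series, on what has been measured and on what is new or still open speak of the compounds shown alone.

Going by the values given here, compound 2 `CC(C)(C)CCc1cnc(CCc2ccc(-c3ccccc3C(=O)O)cc2)[nH]1` gives 6.2 nM in an in vitro functional assay on cells for agonist activity at Bombesin receptor subtype-3 (Mus musculus), read by luminescence and calcium flux (a lower number here means that less compound is needed, a higher number that more compound is needed for the effect), the lower of the two numbers measured so far. Compound 1 `CCCCc1cnc(C(CCCO)Cc2ccc(-c3ccccc3C(=O)O)cc2)[nH]1` gives 238 nM in this assay; the two compounds differ in more than one place, so only their values are set side by side. Compound 3 `Cc1ccccc1Cc1cnc(CCc2ccc(-c3ccccc3C(=O)O)cc2)[nH]1` is the next compound for this assay. Relative to compound 2 the change is 2-methylphenyl in place of neopentyl on a saturated chain carbon bound to an aromatic carbon. Among the compounds with values here, no single-change step between measured compounds is available to set the size; a moderate loss beyond the scatter is expected, a 3.2-fold higher number from compound 2 to compound 3 (0.51 log units; beyond the scatter). Compound 3 is estimated at 20 nM in this assay, with a range of 4 nM to 100 nM.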

Compound 3, half-maximal effective concentration: 9.3 nM
The estimate for compound 3 lay 2.2-fold (0.33 log units) above the measured number; low and high end bracket the measured number.
By their numbers in this assay, from the lowest: compounds 2 and 3 (each within the scatter of the next); then compound 1.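

In this assay, 2-methylphenyl in place of neopentyl gives a 1.5-fold higher number from compound 2 to compound 3 (0.18 log units; within the scatter), the only single-change step among the compounds shown. At this place on a saturated chain carbon bound to an aromatic carbon, a six-membered aromatic ring of carbon only and an open-chain tail therefore cannot be told apart by this read-out. No measured information explains this result. Open, as far as these compounds go, is whether an unsubstituted phenyl, a longer chain or an amine at this place would also stay within the scatter of compound 2.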